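Trading trifluoromethyl for methyl on the oxadiazole of compound 1

A few compounds are considered here, and "the series" means these few. Any claim that something is new, unique, unknown or untested is made for them only; others in the source may bear on it.

Compound 1 `CCN(CC)S(=O)(=O)c1ccc(S(=O)(=O)N2CCC[C@@H](C(=O)N3CCN(c4nc(C(F)(F)F)no4)CC3)C2)cc1` was tested in a functional assay on MIA PaCa-2 cells (Homo sapiens) for inhibition, read by MTT assay, with a stated time of 7 days (a lower number here means a stronger inhibitor, a higher number a weaker inhibitor), where compound 1 gives 600 nM. Within the data shown here, that is the highest of the three numbers so far: compound 2 `CCN(CC)S(=O)(=O)c1ccc(S(=O)(=O)N2CCC[C@@H](C(=O)NC3CCN(C(=O)OC(C)(C)C)CC3)C2)cc1` gives 100 nM, and compound 3 `CC(C)c1noc(N2CCN(C(=O)[C@@H]3CCCN(S(=O)(=O)c4ccc(S(=O)(=O)C5CCC5)cc4)C3)CC2)n1` gives 70 nM, both beyond the scatter from compound 1. Compound 4 `CCN(CC)S(=O)(=O)c1ccc(S(=O)(=O)N2CCC[C@@H](C(=O)N3CCN(c4nc(C)no4)CC3)C2)cc1` differs from compound 1 by a single change, (methyl in place of trifluoromethyl on an aromatic carbon). Among the measured compounds shown here, no pair of measured compounds differs only at this point, so the size of this step is unknown from these data. A step of modest size, if any, is expected, with a slightly weaker inhibitor more likely than a stronger one. Compound 4 is estimated at 800 nM, from 250 nM to 2500 nM, which would mean an expected step of a 1.3-fold higher number from compound 1 to compound 4 (0.12 log units; within the scatter).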

Compound 4, half-maximal inhibitory concentration: 250 nM
Compound 4: the middle estimate sits 3.2-fold (0.51 log units) above what was measured, and the stated range covers the measured number.
By their numbers in this assay, from the lowest: compounds 3 and 2 (each within the scatter of the next); then compound 4; then compound 1.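

Among these compounds, replacing trifluoromethyl with methyl gives a 2.4-fold lower number from compound 1 to compound 4 (0.38 log units; beyond the scatter) in this assay and is the first measured step at this carbon of the oxadiazole. It shows that the group here affects the number, and that with these two groups the one with a single heavy atom gives the stronger inhibitor. Going by these compounds, whether hydrogen, an ethyl group or an amine on this carbon would lower the number further remains open. So does whether the same change would have a similar effect with another sulfonyl group on the core. Nothing measured here accounts for the step.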